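Rearranged side chain on compound 3

This account rests on a few compounds, and the source may have more. Where it says the series, first, only, none or still open, it means among the compounds named here.

In a functional assay on the whole organism for inhibition, with Mus musculus as the target (a lower number here means that less compound is needed, a higher number that more compound is needed for the effect), compound 3 `CCCCNCC(=O)Nc1cccc2c1CN(C)CC2c1ccccc1` gives 32 mg/kg, and compound 2 `CCCCNC(=O)Nc1cccc2c1CN(C)CC2c1ccccc1` gives about 40 mg/kg. These two values lie within the scatter of each other, as a 1.3-fold lower number from compound 2 to compound 3 (0.10 log units; within the scatter) shows. Compound 1 `CCCNC(=O)Nc1cccc2c1CN(C)CC2c1ccccc1` reaches only a limit, > 80 mg/kg. Compound 4 `CC(C)NCCC(=O)Nc1cccc2c1CN(C)CC2c1ccccc1` has the same atoms as compound 3, joined differently: (isopropylamino)methyl in place of butylamino on a saturated chain carbon bound to a carbonyl carbon. Among the compounds with values here, the nearest precedent is a 1.3-fold lower number from compound 2 to compound 3 (0.10 log units; within the scatter), also a change in the chain carrying the amine. an at least 2.5-fold lower number from compound 1 to compound 3 (0.39 log units; beyond the scatter) starts from the limit and gives only a floor. No step beyond the scatter is expected in this assay, and the expected outcome is a 1.1-fold higher number from compound 3 to compound 4 (0.04 log units; within the scatter). For compound 4 the estimate is 35 mg/kg, with an expected range of 15 mg/kg to 80 mg/kg.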

Compound 4, dose for half-maximal effect: 150 mg/kg
Beside the measured number, compound 4's estimate is 4.3-fold (0.63 log units) below it; measured number outside the range, above it.
By their numbers in this assay, from the lowest: compounds 3 and 2 (each within the scatter of the next); then compound 4.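

In this assay, rearranging the same atoms is not neutral: there is a 4.7-fold higher number from compound 3 to compound 4 (0.67 log units; beyond the scatter), with (isopropylamino)methyl in place of butylamino on a saturated chain carbon bound to a carbonyl carbon. The side chain therefore matters here in how it is joined, which the earlier 1.3-fold lower number from compound 2 to compound 3 (0.10 log units; within the scatter) did not show, and a 3.8-fold higher number from compound 2 to compound 4 (0.57 log units; beyond the scatter) points the same way. Compound 1 carries a limit, and its step to compound 4 cannot be read: the limit of > 80 mg/kg in this assay, at which 1 of the 4 values shown sits.

Compound 4 changes branching and the length of the chain before the amine together, so the shift cannot be assigned to either alone. A 2-(butylamino)ethyl or an (isopropylamino)methyl group on the carbonyl carbon would separate the two.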